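This account rests on a few compounds, and the source may have more. Where it says the series, first, only, none or still open, it means among the compounds named here.

Measured so far: compound 1 `CCOc1ccccc1-c1ccc(-c2nc3cnccc3cc2C#N)cc1`, compound 2 `CC[C@@H](Nc1c(C#N)c(-c2ccc(-c3cccc(Cl)c3OC)cc2)nc2cnccc12)C(N)=O`, compound 3 `CC(C)(CC(N)=O)c1c(C#N)c(-c2ccc(Br)cc2)nc2cnccc12`.

In a physicochemical assay for lipophilicity, read by HPLC, at pH 7.5 (a lower number here means a more polar compound, a higher number a more lipophilic compound), compound 1 gives 3.8, the highest of the three numbers. Compound 2 gives 3.1, the nearest to compound 1 and beyond the scatter below it. Compound 3 gives 2.1, the furthest from compound 1 and also beyond the scatter.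

Compound 4 `CCOc1ccccc1-c1ccc(-c2nc3cnccc3c(NC(CC)CNS(=O)(=O)C3CC3)c2C#N)cc1` is not yet measured. It differs from compound 1 by a group of 12 heavy atoms (7 carbon, 2 nitrogen, 2 oxygen, 1 sulfur; one three-membered non-aromatic ring of carbon only) in place of a hydrogen atom, on an aromatic carbon.

Within the data shown here, no step between measured compounds stands behind this change, so its size cannot be read from a measured pair. Compound 4 is expected to fall below compound 1 by a number 0.50 log units lower from compound 1 to compound 4 (beyond the scatter), a step beyond the scatter, because compound 2 at 3.1 and compound 3 at 2.1 both sit under compound 1. Compound 4 is estimated at 3.3, between 2.7 and 3.9.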

Compound 4, distribution coefficient: 3.6
The estimate for compound 4 lay 0.30 log units below the measured number; measured number inside the range.
By their numbers in this assay, from the lowest: compound 3; then compound 2; then compounds 4 and 1 (each within the scatter of the next).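

In this assay, among these compounds, the first step at this position reads a number 0.20 log units lower from compound 1 to compound 4 (within the scatter). On this aromatic carbon, ortho to a cyano group and opposite the ring nitrogen, a group of 12 heavy atoms with 2 hydrogen-bond donors and 3 hydrogen-bond acceptors thus replaces a hydrogen atom without a step beyond the scatter. Nothing on hand accounts for this result.

On these data alone, whether a simple amine or a carboxylic acid on this same carbon would also stay within the scatter of compound 1 remains open.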